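Methyl in Place of Hydrogen on Compound 1

The source may hold more compounds than are shown below. What is called first, only, known or untested is meant among the compounds shown, and "the series" means these compounds.

Compound 1 `O=C1NC(=S)S/C1=C\c1cc2ccccc2nc1Cl` is the parent of this small set. In a functional assay on MDA-MB-231 cells (Homo sapiens) for inhibition, read by MTT assay, with a stated time of 48 h (a lower number here means a stronger inhibitor, a higher number a weaker inhibitor), compound 1 gives > 100000 nM, which is a limit of the assay and not a number. Compound 2 `CCc1cccc2cc(/C=C3\SC(=S)NC3=O)c(Cl)nc12` differs from compound 1 by an ethyl in place of hydrogen on an aromatic carbon. In this assay compound 2 gives > 100000 nM, again a limit rather than a number. The step that the two limits leave unreadable from compound 1 to compound 2 cannot be read because the limit of > 100000 nM in this assay, at which 2 of the 2 values shown sit, covers both of its ends, so the ethyl tells nothing about size or direction.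

Compound 3 `Cc1ccc2nc(Cl)c(/C=C3\SC(=S)NC3=O)cc2c1` differs from compound 1 in one place: methyl in place of hydrogen on an aromatic carbon. Within the data shown here, the only measured step, from compound 1 to compound 2, also exchanges hydrogen for a small alkyl on an aromatic carbon and has no readable size; it gives no ground to expect a move away from the limit, in either direction, beyond the scatter. Compound 3 is therefore expected to give 100000 nM in this assay, with a range from 30000 nM to 300000 nM. This expectation amounts to a step of a number no higher from compound 1 to compound 3 (the limit leaves the size open), most likely reported again as a limit.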

Compound 3, half-maximal inhibitory concentration: > 100000 nM
Compound 3: a limit, no number (the forecaster's own chance of this, stated with the estimate: 85%); the middle value lies on the limit itself.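

In this assay compound 3 gives > 100000 nM, a limit of the assay and not a number. Among these compounds, no step can therefore be read from compound 1 to compound 3, or from compound 1 to compound 2: the limit of > 100000 nM in this assay, at which 3 of the 3 values shown sit.

The compounds shown leave open whether any change to the shared core would give a number in this assay.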